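A few compounds are considered here, and "the series" means these few. Any claim that something is new, unique, unknown or untested is made for them only; others in the source may bear on it.

Series notes on a shared core, read in an ADME assay on cells (Homo sapiens) for cytotoxicity, read by polymerase chain reaction, with a stated time of 3 days; a higher number here means that more compound is tolerated, a lower number that less compound is tolerated. Compound 1 `Nc1nc(Cl)c(-c2nc3ccccc3s2)c(N[C@@H]2C[C@H](CO)[C@@H](O)[C@H]2O)n1` gives 14000 nM. Compound 3 `Cc1nc(NCC(C)C)nc(N[C@@H]2C[C@H](CO)[C@@H](O)[C@H]2O)c1-c1nc2ccccc2s1` gives 10000 nM, which lies within the scatter of compound 1, so the two cannot be ordered. Compound 2 `Nc1nc(Cl)c(-c2nc3ccc(F)cc3s2)c(N[C@@H]2C[C@H](CO)[C@@H](O)[C@H]2O)n1` reaches only a limit in this assay, > 25000 nM. Going by the values given here, the one measured step, an at least 1.7-fold higher number from compound 1 to compound 2 (0.25 log units; that floor lies within the scatter), concerns a fluoro on an aromatic carbon and rests on a limit (the limit of > 25000 nM in this assay, at which 1 of the 3 values shown sits); it offers little bearing on the move to compound 4 `Cc1nc(Nc2ncco2)nc(N[C@@H]2C[C@H](CO)[C@@H](O)[C@H]2O)c1-c1nc2ccccc2s1`, which carries 1,3-oxazol-2-yl in place of isobutyl on a nitrogen on an aromatic ring. Among the compounds with values here, no measured pair tests an exchange on that nitrogen. The expectation is therefore no step beyond the scatter, no change at the digits printed from compound 3 to compound 4 (within the scatter). Compound 4 is estimated at 10000 nM, with a range from 4000 nM to 25000 nM.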

Compound 4, half-maximal cytotoxic concentration: > 25000 nM
Compound 4: only a limit was reported; the forecaster's own chance of this, stated with the estimate: 20%; middle value at least 2.5-fold (0.39 log units) away from the limit.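

On a nitrogen on an aromatic ring, the exchange of isobutyl for 1,3-oxazol-2-yl moves the read-out in this assay, giving an at least 2.5-fold higher number from compound 3 to compound 4 (0.39 log units; beyond the scatter). Going by these compounds alone, the earlier fluoro step has a floor within the scatter, so this is the first step that can be read as a change. Its full size stays unknown, since compound 4 gives only a limit: the limit of > 25000 nM in this assay, at which 2 of the 4 values shown sit.

Going by these compounds, whether the rise follows from the 1,3-oxazol-2-yl ring itself or from the loss of isobutyl remains open. A free amine or a phenyl on that nitrogen would separate the two.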